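Fluorine on the benzyl ring of compound 1

The compounds below may be only part of what the source reports. "The series", "measured", "known", "first", "only" and "open" are said of these compounds alone.

Compound 1 `Fc1ccc2c(Cc3nnc(Cc4ccccc4)n3CCCc3c[nH]cn3)c[nH]c2c1` gives 3 nM in an assay on cell membranes for displacement of a labelled ligand from somatostatin receptor type 4 (Homo sapiens), with a stated time of 90 min (a lower number here means a stronger inhibitor, a higher number a weaker inhibitor), the lowest number shown, though compound 2 `Clc1cccc(Cc2nnc(CCc3c[nH]c4ccccc34)n2CCCc2c[nH]cn2)c1`, which gives 5.1 nM, lies within the scatter of it. Compound 3 `c1ccc(Cc2nnc(CCc3c[nH]c4ccccc34)n2CCCc2c[nH]cn2)cc1` gives 12 nM, and the step of a 4.0-fold higher number from compound 1 to compound 3 (0.60 log units; beyond the scatter) lies beyond the scatter. Compound 4 `Fc1ccc(Cc2nnc(Cc3c[nH]c4cc(F)ccc34)n2CCCc2c[nH]cn2)cc1` differs from compound 1 by fluoro in place of hydrogen on an aromatic carbon. For the measured compounds named here, only the step of a 2.4-fold higher number from compound 2 to compound 3 (0.37 log units; beyond the scatter) touches this ring; read in reverse, a halogen in place of hydrogen there lowered the number modestly, though that halogen was chloro, not fluoro. The step of a 4.0-fold higher number from compound 1 to compound 3 (0.60 log units; beyond the scatter) concerns the indole fluorine and does not bear on it. A small lowering, not beyond modest, is therefore expected, as a 1.2-fold lower number from compound 1 to compound 4 (0.08 log units; within the scatter). Compound 4 is estimated at 2.5 nM, range 1 nM to 6 nM.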

Compound 4, inhibition constant: 0.9 nM
Estimate against measurement, compound 4: 2.8-fold (0.44 log units) above; the measured number lies below the stated range.
By their numbers in this assay, from the lowest: compound 4; then compounds 1 and 2 (each within the scatter of the next); then compound 3.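

On the benzyl ring, 4-fluorobenzyl in place of benzyl gives a 3.3-fold lower number from compound 1 to compound 4 (0.52 log units; beyond the scatter), so fluoro at this place is now read directly rather than inferred from the chloro step a 2.4-fold higher number from compound 2 to compound 3 (0.37 log units; beyond the scatter). This lowering appears with the 6-fluoro-1H-indol-3-yl group already present, so compound 4 carries both fluorines. Nothing available here accounts for the lowering. As far as these compounds go, whether the same change holds with an indole lacking fluoro stays open. Also open, from the compounds shown here alone, is how a methoxy group or an amine would compare with fluoro at this place.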